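Trimming One Methoxy Group from a Cytotoxic Dienone

The source may report more compounds than this note shows. Statements on the series, on what has been measured and on what is new or still open speak of the compounds shown alone.

Compound 2 `COc1cc(/C=C2\Cc3ccccc3/C(=C\c3ccc([N+](=O)[O-])cc3)C2=O)cc(OC)c1OC` gives the lowest number of those shown in a functional assay on HL-60 cells (Homo sapiens) for cytotoxicity (on this read-out lower numbers stand for higher toxicity in this test and higher numbers for lower toxicity in this test), namely 550 nM. Compound 3 `COc1cc(/C=C2/C(=O)/C(=C/c3ccc([N+](=O)[O-])cc3)c3ccccc32)cc(OC)c1OC`, which joins the same building blocks in a different arrangement, gives 318000 nM in this assay, a far higher number and well beyond the usual scatter. Compound 1 `COc1cc(/C=C2\CC/C(=C\c3ccc([N+](=O)[O-])cc3)C2=O)cc(OC)c1OC` gives > 400000 nM, which is a limit of the assay rather than a measured number (the limit of > 400000 nM in this assay, at which 1 of the 3 values shown sits).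

Compound 4 `COc1ccc(/C=C2\Cc3ccccc3/C(=C\c3ccc([N+](=O)[O-])cc3)C2=O)cc1OC` differs from compound 2 in a single place: hydrogen in place of methoxy on an aromatic carbon. Going by the values given here, no measured pair of this kind exists here, so the expectation rests on the change alone; a modest rise in the number is expected, a 2.7-fold higher number from compound 2 to compound 4 (0.44 log units; beyond the scatter). Compound 4 is therefore estimated at 1500 nM, with a range from 400 nM to 8000 nM.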

Compound 4, half-maximal cytotoxic concentration: 560 nM
Compound 4: the middle estimate sits 2.7-fold (0.43 log units) above what was measured; the measured number falls inside the stated range.
By their numbers in this assay, from the lowest: compounds 2 and 4 (each within the scatter of the next); then compound 3. At a limit, above all of these: compound 1.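

In this assay, hydrogen in place of methoxy on this aromatic carbon gives a 1.0-fold higher number from compound 2 to compound 4 (0.01 log units; within the scatter) and so shows that this methoxy group can be lost with no change that can be told from the scatter. The earlier compounds shown here all carry this methoxy group, so they could not show this. Nothing measured here says why the number holds.

As far as these compounds go, whether the other methoxy groups can go as well remains open. So does the outcome of an amine or a carboxylic acid on this same aromatic carbon.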